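Lengthening the Ureido Group of Compound 3

A few compounds are considered here, and "the series" means these few. Any claim that something is new, unique, unknown or untested is made for them only; others in the source may bear on it.

Three compounds were measured in a functional assay on Ehrlich cells (Mus musculus) for cytotoxicity, read by trypan blue exclusion, with a stated time of 2 h, tested at 10 ug/mL; on this read-out higher numbers stand for a stronger effect at the one concentration tested and lower numbers for a weaker effect:
compound 1 `N#CC1=C(N)N(c2ccc(S(N)(=O)=O)cc2)C2=C(C(=O)CCC2)C1c1ccc(Cl)cc1Cl` gives 40%
compound 2 `C=CCNC(=S)NC1=C(C#N)C(c2ccc(Cl)cc2Cl)C2=C(CCCC2=O)N1c1ccc(S(N)(=O)=O)cc1` gives 10%
compound 3 `N#CC1=C(NC(N)=O)N(c2ccc(S(N)(=O)=O)cc2)C2=C(C(=O)CCC2)C1c1ccc(Cl)cc1Cl` gives 20%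

Compound 3 stands second highest of the three. Its nearest neighbour is compound 2, with a number 10 percentage points higher from compound 2 to compound 3 (within the scatter), a difference within the scatter. Its furthest neighbour is compound 1, with a number 20 percentage points lower from compound 1 to compound 3 (beyond the scatter), a modest step beyond the scatter.

Compound 4 `N#CC1=C(NC(=O)CCC(=O)O)N(c2ccc(S(N)(=O)=O)cc2)C2=C(C(=O)CCC2)C1c1ccc(Cl)cc1Cl` has not been measured. It differs from compound 3 as follows: 2-carboxyethyl in place of amino on a carbonyl carbon.

Going by the values given here, two measured steps bear on this change, both acting at the same amine nitrogen of the shared core. Replacing hydrogen with carbamoyl gave a number 20 percentage points lower from compound 1 to compound 3 (beyond the scatter), and replacing hydrogen with the larger acyclic group gave a number 30 percentage points lower from compound 1 to compound 2 (beyond the scatter). Exchanging one appended group for another gave only a number 10 percentage points higher from compound 2 to compound 3 (within the scatter), a difference within the scatter. Growing the group further from compound 3 is therefore expected to give at most a small step in this assay, most likely downward, and the expected a number 5 percentage points lower from compound 3 to compound 4 (within the scatter) lies within the usual scatter.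

Compound 4 is accordingly estimated at 15%, with a range from 5% to 30%.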

Compound 4, a percentage reported as activity, at one concentration (the size of the read-out at that concentration, not a potency): 20%
For compound 4 the middle estimate is 5 percentage points below the measured one; measured number inside the range.
By their numbers in this assay, from the lowest: compounds 2, 3 and 4 (each within the scatter of the next); then compound 1.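

On the carbonyl carbon whose other neighbour is the amide-type nitrogen, 2-carboxyethyl takes the place of amino with no change at the digits printed from compound 3 to compound 4 (within the scatter) in this assay, so this position tolerates a longer chain ending in a carboxylic acid without any reading that separates it from the ureido compound. Set against the unsubstituted amine, (2-carboxyethyl)carbonyl on the amine nitrogen gives a number 20 percentage points lower from compound 1 to compound 4 (beyond the scatter), and with a number 10 percentage points higher from compound 2 to compound 4 (within the scatter) all three substituted compounds now lie within the scatter of one another, each beyond the scatter of compound 1, whichever of these three groups the nitrogen carries. No accompanying evidence bears on this result.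

From the compounds shown here alone, it remains open whether a methyl ester in place of the carboxylic acid, a longer 3-carboxypropyl chain or a chain ending in an amine would stay with these three compounds or come back towards compound 1. Because the read-out rests on one concentration, the compounds shown also leave open whether the equal readings of compound 3 and compound 4 would hold at other concentrations.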